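Branched alkyl in place of methylpyrrolyl on the shared core

A few compounds are considered here, and "the series" means these few. Any claim that something is new, unique, unknown or untested is made for them only; others in the source may bear on it.

The two measured compounds share a core that differs only in the group attached on one aromatic carbon. Compound 1 `CCCn1c(=O)c2nc([C@@H]3CC4CCC3C4)[nH]c2n(CCC)c1=O` carries a saturated bicyclic group there, and in an assay on cell membranes for binding affinity to adenosine receptor A1 (Cavia porcellus), read by radioligand binding (on this read-out higher numbers stand for weaker inhibition and lower numbers for stronger inhibition), compound 1 gives 3.8 nM. Within the data shown here, compound 2 `CCCn1c(=O)c2nc(-c3cccn3C)[nH]c2n(CCC)c1=O` carries a 1-methyl-1H-pyrrol-2-yl group at the same place, and in this assay compound 2 gives 140 nM, the highest of the two numbers; the only step to it is a 37-fold higher number from compound 1 to compound 2 (1.57 log units; beyond the scatter).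

Compound 3 `CCCn1c(=O)c2nc(C(C)(C)CCC)[nH]c2n(CCC)c1=O` is not yet measured. Its difference from compound 2 is 1,1-dimethylbutyl in place of 1-methyl-1H-pyrrol-2-yl on an aromatic carbon. Among the measured compounds shown here, no measured step replaces an aromatic ring by an acyclic chain, so the one step that bears on it is indirect: it shows that a carbon-only group without aromatic ring, as in compound 1 with 3.8 nM, comes with a far lower number than the methylpyrrolyl group of compound 2. A step of a 7.0-fold lower number from compound 2 to compound 3 (0.85 log units; beyond the scatter) is therefore expected, toward a lower number but not reaching compound 1. Compound 3 is estimated at 20 nM in this assay, within 5 nM to 80 nM.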

Compound 3, inhibition constant: 25 nM
For compound 3 the middle estimate is 1.3-fold (0.10 log units) below the measured one; low and high end bracket the measured number.
By their numbers in this assay, from the lowest: compound 1; then compound 3; then compound 2.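

Compound 3 shows that a ring is not needed on this aromatic carbon, between two ring nitrogen atoms, for a number lower than that of compound 2: at an unchanged count of heavy atoms, putting 1,1-dimethylbutyl in place of 1-methyl-1H-pyrrol-2-yl gives a 5.6-fold lower number from compound 2 to compound 3 (0.75 log units; beyond the scatter) in this assay, a step beyond the scatter. The open chain does not match the saturated bicyclic group, however, as a 6.6-fold higher number from compound 1 to compound 3 (0.82 log units; beyond the scatter) separates these two carbon-only groups, so the position still distinguishes between them. Among these three compounds, both carbon-only groups therefore give lower numbers than the nitrogen-containing aromatic group, and none of the three goes against this, although compound 3 lies well apart from compound 1.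

The compounds shown leave open whether the step from compound 2 follows the loss of the aromatic ring or the loss of its nitrogen, which a plain phenyl group could separate, and whether an unbranched pentyl chain or an amine on the chain would fit the same order. No accompanying measurement offers an explanation for the differences between these groups.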